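Swapping One Ring Atom on an Inactive Sulfone

A few compounds are considered here, and "the series" means these few. Any claim that something is new, unique, unknown or untested is made for them only; others in the source may bear on it.

Compound 1 `O=S(=O)(CC1=NCCS1)c1c(-c2ccccc2)nn(-c2ccccc2)c1-c1ccccc1`: "not active" (no number reported)
Compound 2 `O=S(=O)(CC1=NCCS1)c1c(-c2ccc(Cl)cc2)noc1-c1ccc(Cl)cc1`: "not active" (no number reported)
Compound 3 `COc1ccc(C2=NOC(c3ccc(C)cc3)C2S(=O)(=O)CC2=NCCS2)cc1`: 47.5%

Three compounds were tested in a functional assay, tested at 50 ug/mL; a lower number here means a weaker effect, a higher number a stronger effect of the compound at the concentration tested. Compound 1 and compound 2 were both reported without a number: in this assay compound 1 gave "not active" (no number reported) and compound 2 gave "not active" (no number reported). Only compound 3 came back with a figure; in this assay compound 3 gave 47.5%. Compound 2 therefore stands at the bottom of what is known here, together with compound 1, with no number of its own to compare against compound 3.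

The step of interest leads from compound 2 to compound 4 `O=S(=O)(CC1=NCCO1)c1c(-c2ccc(Cl)cc2)noc1-c1ccc(Cl)cc1`. The change is a small one: a group of 5 heavy atoms (3 carbon, 1 nitrogen, 1 oxygen; one five-membered non-aromatic ring with 2 hetero atoms) in place of a group of 5 heavy atoms (3 carbon, 1 nitrogen, 1 sulfur; one five-membered non-aromatic ring with 2 hetero atoms), on a saturated chain carbon bound to a sulfonyl sulfur. Everything else in compound 2, including both chlorinated phenyl groups and the sulfonyl linker, is kept.

Among the compounds with values here, since no pair of measured compounds differs in just one place, no measured step is available to set a size for this change. With compound 2 showing no effect at all, the expectation for this assay is no rise beyond the usual scatter, or at most a small one.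

Compound 4 is expected to give 10% in this assay, within a range from 0% to 30%.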

Compound 4, a percentage reported as activity, at one concentration (the size of the read-out at that concentration, not a potency): "not active" (no number reported)
For compound 4 the study gives words and no number; the estimate stays without a comparison.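

In this assay compound 2 and compound 4 were both reported without a number, so no step can be read between them. Still open, from the compounds shown here alone, is whether the same ring swap would change the effect of a compound with a measurable read-out, such as compound 3 at 47.5%. No supporting measurement shown here bears on this result.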